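Chain extension in a cytotoxicity series

A few compounds are considered here, and "the series" means these few. Any claim that something is new, unique, unknown or untested is made for them only; others in the source may bear on it.

Compound 1 `CCCCCCCC(=O)C1=C(O)/C(=C/c2ccccc2)N(C(C)=O)C1=O`, compound 2 `CCCCCCCCCC(=O)C1=C(O)/C(=C/c2ccccc2)N(C(C)=O)C1=O` and compound 3 `CCCCCCCCCCCCCC(=O)C1=C(O)/C(=C/c2ccccc2)N(C(C)=O)C1=O` share one core and differ only in the saturated chain. In an ADME assay on HEK293 cells (Homo sapiens) for cytotoxicity (on this read-out higher numbers stand for lower toxicity in this test and lower numbers for higher toxicity in this test), compound 1 gives a limit of the assay, > 32 ug/mL. Compound 2 likewise reaches only a limit in this assay, > 32 ug/mL. Compound 3 also stands at a limit in this assay, > 32 ug/mL. The steps a step that the two limits leave unreadable from compound 1 to compound 2, a step that the two limits leave unreadable from compound 1 to compound 3 and a step that the two limits leave unreadable from compound 2 to compound 3 thus carry no readable size, all three values sitting at the limit of > 32 ug/mL in this assay, at which 3 of the 3 values shown sit. Compound 4 `CCCCCCCCCCCCCCCC(=O)C1=C(O)/C(=C/c2ccccc2)N(C(C)=O)C1=O` differs from compound 3 by ethyl in place of hydrogen on a saturated chain carbon, ten or more bonds along the chain from a carbonyl carbon. The three unreadable chain steps bear on this change but show no direction. A step that the limit leaves unreadable from compound 3 to compound 4 is expected, none beyond the scatter. Compound 4 is expected to give 40 ug/mL in this assay, within 20 ug/mL to 80 ug/mL.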

Compound 4, half-maximal cytotoxic concentration: > 32 ug/mL
Compound 4 ended at the assay's limit; the forecaster's own chance of this, stated with the estimate: 75%; the middle value does not contradict the limit.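

For the compounds shown here, no step to compound 4 from compound 1, compound 2 or compound 3 can be read in this assay, since all four values are limits of the assay: the limit of > 32 ug/mL in this assay, at which 4 of the 4 values shown sit. The compounds shown leave open how chain length affects cytotoxicity, as none gives a value inside the assay's range.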